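A few compounds are considered here, and "the series" means these few. Any claim that something is new, unique, unknown or untested is made for them only; others in the source may bear on it.

Measured compounds:
Compound 1 `Cc1c(OC2CCN(C)CC2)ccc2cc(NC(=O)c3ccc4c(c3)CCC(C)(C)O4)c(=O)oc12`: 5010 nM
Compound 2 `Cc1c(OC2CCN(C)CC2)ccc2cc(NC(=O)c3ccccc3)c(=O)oc12`: 11700 nM

In a functional assay on MCF7 cells (Homo sapiens) for antiproliferative activity (on this read-out lower numbers stand for stronger inhibition and higher numbers for weaker inhibition), compound 2 gives 11700 nM, the higher of the two numbers and a weaker result than compound 1, a gap beyond the usual scatter. Compound 3 `Cc1c(OC2CCN(C)CC2)ccc2cc(NC(=O)c3ccc(O)c(Cl)c3)c(=O)oc12` has not yet been measured. It carries 3-chloro-4-hydroxyphenyl in place of phenyl on a carbonyl carbon. For the measured compounds named here, no pair of measured compounds differs in one place, so the data offer no direct precedent for this change. Going by the values given here, the only guide is that compound 1 stands lower, at 5010 nM, and a modest move towards stronger inhibition is therefore expected, one that may not clear the scatter. The expected change is a 1.7-fold lower number from compound 2 to compound 3 (0.22 log units; within the scatter). For compound 3 the estimated value is 7000 nM, with an expected range from 2500 nM to 20000 nM.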

Compound 3, half-maximal inhibitory concentration: 1480 nM
For compound 3 the middle estimate is 4.7-fold (0.67 log units) above the measured one, and the stated range ends above it.
By their numbers in this assay, from the lowest: compound 3; then compound 1; then compound 2.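

In this assay, placing 3-chloro-4-hydroxyphenyl in place of phenyl on a carbonyl carbon gives a 7.9-fold lower number from compound 2 to compound 3 (0.90 log units; beyond the scatter). This shows that, with the rest of the molecule unchanged, the read-out responds strongly to substitution on this aryl group, and the number for compound 3 also lies lower than that of compound 1, at 5010 nM. No measurement shown here accounts for the size of this step.

The compounds shown leave open whether the chlorine, the hydroxyl or the two together carry the step, a question that 3-chlorophenyl and 4-hydroxyphenyl on the same carbonyl carbon would separate. Also open, from the compounds shown here alone, is how a methoxy group or an amine in place of the hydroxyl would read.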